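The compounds below may be only part of what the source reports. "The series", "measured", "known", "first", "only" and "open" are said of these compounds alone.

Working notes on the series. In a functional assay on U2OS cells for antagonist activity at C-X-C chemokine receptor type 3 (Homo sapiens), read by beta-arrestin recruitment (a lower number here means a stronger inhibitor, a higher number a weaker inhibitor), compound 1 `CCOc1ncc(-c2nc(C(F)(F)F)sc2N2CCN(C(=O)Cn3nc(C)nc3C)[C@H](C)C2)cn1` gives 173 nM. Compound 2 `CCc1ncc(-c2nc(C(F)(F)F)sc2N2CCN(C(=O)Cn3nc(C)nc3C)[C@H](C)C2)cn1` gives 1430 nM in this assay, and compound 3 `Cc1nc(C)n(CC(=O)N2CCN(c3sc(C(F)(F)F)nc3-c3cnc(C(C)(C)C)nc3)C[C@H]2C)n1` gives 1030 nM. Compound 3 thus stands second highest of the three numbers: its nearest neighbour is compound 2, with the gap a 1.4-fold lower number from compound 2 to compound 3 (0.14 log units; within the scatter) lying within the scatter, while its furthest is compound 1, with a 6.0-fold higher number from compound 1 to compound 3 (0.77 log units; beyond the scatter) lying beyond it.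

Compound 4 `CCOc1ccc(-c2nc(C(F)(F)F)sc2N2CCN(C(=O)Cn3nc(C)nc3C)[C@H](C)C2)cn1` differs from compound 3 by 6-ethoxypyridin-3-yl in place of 2-(tert-butyl)pyrimidin-5-yl on an aromatic carbon. Among the measured compounds shown here, two measured steps bear on it. Both replacements of ethoxy by a carbon-linked group raised the number: an 8.3-fold higher number from compound 1 to compound 2 (0.92 log units; beyond the scatter) and a 6.0-fold higher number from compound 1 to compound 3 (0.77 log units; beyond the scatter). For the measured compounds named here, compound 4 reverses that direction, putting ethoxy back, although now on a pyridinyl rather than a pyrimidinyl ring; no measured pair shows the pyrimidinyl-to-pyridinyl exchange on its own. A lower number is therefore expected for compound 4 in this assay, of a size near the reverse of the step from compound 1 to compound 3, that is a 4.1-fold lower number from compound 3 to compound 4 (0.61 log units; beyond the scatter). Compound 4 is estimated at 250 nM, with a range from 80 nM to 800 nM.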

Compound 4, half-maximal inhibitory concentration: 505 nM
The estimate for compound 4 lay 2.0-fold (0.31 log units) below the measured number; measured number inside the range.
By their numbers in this assay, from the lowest: compound 1; then compound 4; then compounds 3 and 2 (each within the scatter of the next).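

In this assay, 6-ethoxypyridin-3-yl keeps an advantage over both carbon-linked pyrimidinyl groups, with a 2.0-fold lower number from compound 3 to compound 4 (0.31 log units; beyond the scatter) and a 2.8-fold lower number from compound 2 to compound 4 (0.45 log units; beyond the scatter) both beyond the scatter. Among the compounds shown here, with ethoxy held in place, the ring itself now proves to matter at this position: a 2.9-fold higher number from compound 1 to compound 4 (0.47 log units; beyond the scatter) is the first measured exchange of pyrimidinyl for pyridinyl, and it goes against the pyridinyl ring. No measurement available here bears on the origin of these differences.

The compounds shown leave open whether ethyl or tert-butyl on the pyridinyl ring would cost as much as on the pyrimidinyl ring. Also open, on these data alone, is how a longer chain such as propoxy, or an amine such as dimethylamino, in place of ethoxy would fare on either ring.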